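Shortening an unsaturated amide on a piperidine ring

The source may report more compounds than this note shows. Statements on the series, on what has been measured and on what is new or still open speak of the compounds shown alone.

Measured compounds:
compound 1 `O=C(CCl)N1CCCC(n2nc(-c3ccc(Oc4ccccc4)cc3)cc2CO)C1` — in a functional assay on Rec1 cells (Homo sapiens) for inhibition, read by luminescence and CellTiter-Glo, with a stated time of 72 h (on this read-out lower numbers stand for stronger inhibition and higher numbers for weaker inhibition), compound 1 gives 400 nM
compound 2 `O=C(CCl)Nc1cccc(Cn2nc(-c3ccc(Oc4ccccc4)cc3)cc2CO)c1` — in this assay compound 2 gives 400 nM
compound 3 `C/C=C/C(=O)N1CCCC(n2nc(-c3ccc(Oc4ccccc4)cc3)cc2C(=O)OCC)C1` — in this assay compound 3 gives 5100 nM

Compound 3 stands at the highest of the three numbers, so it is the weakest inhibitor in this group. Its nearest neighbours are compound 1 and compound 2, both of which sit at a markedly lower number, well beyond the usual scatter. Compound 3 differs from those two in more than one place, so what drives its weaker inhibition cannot be read from these numbers alone.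

The next compound is compound 4 `C=CC(=O)N1CCCC(n2nc(-c3ccc(Oc4ccccc4)cc3)cc2C(=O)OCC)C1`. It differs from compound 3 in a single spot: vinyl in place of prop-1-en-1-yl on a carbonyl carbon. Among the compounds with values here, since no pair of measured compounds differs in just this way, there is no directly comparable step to rest on. Within the data shown here, the change is small in atom count, and with no closely related precedent the expectation is a modest move towards stronger inhibition, uncertain in size. In this assay compound 4 is expected to give about 1200 nM, within a range of 300 nM to 4500 nM, an estimated step of a 4.3-fold lower number from compound 3 to compound 4 (0.63 log units; beyond the scatter).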

Compound 4, half-maximal inhibitory concentration: 13800 nM
The estimate for compound 4 lay 12-fold (1.06 log units) below the measured number; measured number above the stated range.
By their numbers in this assay, from the lowest: compounds 1 and 2 (each within the scatter of the next); then compound 3; then compound 4.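

Within the data shown here, this is the first comparison in the set that changes one thing only. With vinyl in place of prop-1-en-1-yl on a carbonyl carbon, this assay shows a 2.7-fold higher number from compound 3 to compound 4 (0.43 log units; beyond the scatter), so on this read-out the smaller group gives modestly weaker inhibition, and at this position in this ethyl ester series shortening the unsaturated chain brings no gain. Nothing shown explains why the number moves in this direction.

From the compounds shown here alone, whether a longer chain or an amine in place of prop-1-en-1-yl on this carbonyl carbon would give stronger or weaker inhibition stays open. So does whether the same step would appear in compounds carrying hydroxymethyl instead of the ethyl ester, and what separates compound 1 and compound 2 from this pair, since they differ from it in more than one place.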